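Methylating a phenol on a nitrate-bearing caffeate ester

This account rests on a few compounds, and the source may have more. Where it says the series, first, only, none or still open, it means among the compounds named here.

Compound 1 `O=C(/C=C/c1ccc(O)c(O)c1)OCc1c(-c2ccccc2)no[n+]1[O-]`: 2540 nM
Compound 2 `COc1cc(/C=C/C(=O)OCc2c(-c3ccccc3)no[n+]2[O-])ccc1O`: 7030 nM
Compound 3 `O=C(/C=C/c1ccc(OCCCCCCO[N+](=O)[O-])c(O)c1)OCCCCCCO[N+](=O)[O-]`: > 50000 nM

In a functional assay on NCI-H460 cells (Homo sapiens) for cytotoxicity, read by resazurin assay, with a stated time of 72 h (a higher number here means a weaker inhibitor, a lower number a stronger inhibitor), compound 1 gives 2540 nM. Compound 2 differs by methyl in place of hydrogen on an oxygen on an aromatic ring, and the result is a 2.8-fold higher number from compound 1 to compound 2 (0.44 log units; beyond the scatter). Compound 3 carries a different core; how that core differs from compound 1 is not broken down here. In this assay compound 3 reaches only a limit, > 50000 nM, as noted in the limit of > 50000 nM in this assay, at which 1 of the 3 values shown sits. Compound 4 `COc1cc(/C=C/C(=O)OCCCCCCO[N+](=O)[O-])ccc1OCCCCCCO[N+](=O)[O-]` is not yet measured; it differs from compound 3 by methyl in place of hydrogen on an oxygen on an aromatic ring, the same change as before at a place described in the same words. Since that change weakened compound 1 into compound 2, compound 4 is expected to be at or beyond the limit, with an estimated step that the limit leaves unreadable from compound 3 to compound 4. Compound 4 is estimated at 120000 nM, between 50000 nM and 400000 nM.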

Compound 4, half-maximal inhibitory concentration: > 50000 nM
Compound 4 gave a limit, no number; the forecaster's own chance of this, stated with the estimate: 85%; the middle value is on the limit's open side.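

Compound 3 and compound 4 both stop at a limit rather than a number, so the step between them cannot be read: the limit of > 50000 nM in this assay, at which 2 of the 4 values shown sit.

On these data alone, whether hydroxy to methoxy weakens compound 3 as it weakened compound 1 stays open.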